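A few compounds are considered here, and "the series" means these few. Any claim that something is new, unique, unknown or untested is made for them only; others in the source may bear on it.

Compound 1 `O=C(/C=C/c1ccc([N+](=O)[O-])o1)c1ccc(Br)cc1`: 13400 nM
Compound 2 `O=C(/C=C/c1ccc(Cl)s1)c1ccc(-n2ccnc2)cc1`: > 50000 nM, a limit of the assay

Of the compounds shown here, two have been measured in an ADME assay on THP-1 cells (Homo sapiens) for cytotoxicity, read by resazurin assay, with a stated time of 72 h; a higher number here means that more compound is tolerated, a lower number that less compound is tolerated. Among the measured compounds shown here, compound 1 gives 13400 nM, the only actual number among the two values shown. Compound 2 sits at the limit of > 50000 nM in this assay, at which 1 of the 2 values shown sits, which is a limit of the assay and not a number. For the measured compounds named here, compound 1 therefore stands as the sole compound with a measured figure, and any comparison has to start from it.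

Compound 3 `O=C(/C=C/c1ccc([N+](=O)[O-])o1)c1ccc(N2CCCC2)cc1` differs from compound 1 in one place: pyrrolidin-1-yl in place of bromo on an aromatic carbon. Going by the values given here, no pair of measured compounds differs in a single place, so no measured step guides this change. In this assay the step is expected to be small, with no clear direction beyond the usual scatter. Compound 3 is accordingly expected to give about 15000 nM, in a range from 5000 nM to 45000 nM. That expectation corresponds to a step of a 1.1-fold higher number from compound 1 to compound 3 (0.05 log units; within the scatter).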

Compound 3, half-maximal cytotoxic concentration: > 50000 nM
Compound 3 gave a limit, no number; the forecaster's own chance of this, stated with the estimate: 15%; at least 3.3-fold (0.52 log units) between middle value and limit.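

Among the compounds shown here, the first comparison in a single place comes from this pair: with pyrrolidin-1-yl in place of bromo on the aromatic carbon para to a large group, this assay shows an at least 3.7-fold higher number from compound 1 to compound 3 (0.57 log units; beyond the scatter). The earlier compounds shown here offered no such step, and this one shows that the group at this position can move the tolerated concentration beyond the scatter, towards more compound tolerated. The value of compound 3 is a limit of the assay and not a number, and it shares that ceiling with one other compound: the limit of > 50000 nM in this assay, at which 2 of the 3 values shown sit.

As far as these compounds go, the true size of the step therefore remains unknown. From the compounds shown here alone, it also remains open whether this shift is particular to pyrrolidin-1-yl or would also appear with an open-chain amine such as dimethylamino, with morpholin-4-yl or with a carboxylic acid at the same place.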